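The source may report more compounds than this note shows. Statements on the series, on what has been measured and on what is new or still open speak of the compounds shown alone.

Compound 1 `CC(=O)N(C)C(C)C#CCn1cncc1C` and compound 2 `CC(=O)N(C)CC#CCn1cncc1C` are built on one core, while compound 3 `COC(=O)N(C)CC#CCN1CCCC1` rests on a second core; the difference between the two cores is not broken down here. In a functional assay on the whole organism for antagonist activity, with Mus musculus as the target (a higher number here means that more compound is needed for the effect, a lower number that less compound is needed), compound 1 gives 1.1 mg/kg. In this assay compound 2 gives 6.6 mg/kg. For compound 3 this assay reports only a limit of > 10 mg/kg. The change from compound 2 to compound 1 is methyl in place of hydrogen on a saturated chain carbon bound to an amide-type nitrogen and a triple-bonded carbon, and it made a 6.0-fold lower number from compound 2 to compound 1 (0.78 log units; beyond the scatter). Compound 4 `COC(=O)N(C)C(C)C#CCN1CCCC1` has not yet been measured; it differs from compound 3 by methyl in place of hydrogen on a saturated chain carbon bound to an amide-type nitrogen and a triple-bonded carbon, the same change carried onto the other core. Whether the same step follows is open: compound 3 stands at the limit of > 10 mg/kg in this assay, at which 1 of the 3 values shown sits, so there is no number to step from, and the two cores differ in more than one place. Guided by a 6.0-fold lower number from compound 2 to compound 1 (0.78 log units; beyond the scatter), a step in the same direction but of smaller size is expected, an at least 1.2-fold lower number from compound 3 to compound 4 (0.09 log units; that floor lies within the scatter). Compound 4 is therefore estimated to give 8 mg/kg in this assay, with a likely range from 2 mg/kg to 30 mg/kg.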

Compound 4, dose for half-maximal effect: > 100 mg/kg
Compound 4 ended at the assay's limit (the forecaster's own chance of this, stated with the estimate: 40%); middle value at least 12-fold (1.09 log units) from the limit.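

In this assay compound 3 gives only a limit, > 10 mg/kg. Compound 4 also gives only a limit, > 100 mg/kg. With two limits, no step can be read between compound 3 and compound 4. The compounds shown leave open how far methyl in place of hydrogen moves the number on the core of compound 3, and in which direction.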